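Removing the side chain from compound 2

This account rests on a few compounds, and the source may have more. Where it says the series, first, only, none or still open, it means among the compounds named here.

compound 1 `CN1CCN(CCCn2c3c(c4ccccc42)C(=O)c2c[n+]([O-])c4ccccc4c2C3=O)CC1`: 470 nM
compound 2 `CN1CCN(CCCCCn2c3c(c4ccccc42)C(=O)c2c[n+]([O-])c4ccccc4c2C3=O)CC1`: 1710 nM

Among the compounds with values here, in a functional assay on A-375 cells (Homo sapiens) for cytotoxicity, read by MTT assay, with a stated time of 72 h (a lower number here means a stronger inhibitor, a higher number a weaker inhibitor), compound 2 gives 1710 nM, the higher of the two numbers measured so far. Within the data shown here, the only measured step is a 3.6-fold higher number from compound 1 to compound 2 (0.56 log units; beyond the scatter). It lies beyond the scatter and comes with 2-(4-methylpiperazin-1-yl)ethyl in place of 4-methylpiperazin-1-yl on a saturated chain carbon.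

Compound 3 `O=C1c2c[n+]([O-])c3ccccc3c2C(=O)c2[nH]c3ccccc3c21` is the next to be tested. Its difference from compound 2 is hydrogen in place of 5-(4-methylpiperazin-1-yl)pentyl on an aromatic nitrogen. Among the measured compounds shown here, no measured compound lacks this side chain, so the one measured step bears on the change only indirectly. It alters the chain rather than removing it. Still, compound 1, at 470 nM, suggests a lower number as the chain is cut back, so a modest step in that direction is expected, with wide uncertainty. The expected change is a 2.1-fold lower number from compound 2 to compound 3 (0.33 log units; beyond the scatter). For compound 3 the estimated value is 800 nM, with an expected range from 150 nM to 4000 nM.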

Compound 3, half-maximal inhibitory concentration: 660 nM
Compound 3: middle estimate off by 1.2-fold (0.08 log units), on the high side; measured number inside the range.
By their numbers in this assay, from the lowest: compounds 1 and 3 (each within the scatter of the next); then compound 2.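

In this assay the removal of the 5-(4-methylpiperazin-1-yl)pentyl group from the aromatic nitrogen gives a 2.6-fold lower number from compound 2 to compound 3 (0.41 log units; beyond the scatter) and so shows that the shared core, with only hydrogen on that nitrogen, needs no side chain to reach this level of cytotoxicity. Hydrogen in place of the shorter 3-(4-methylpiperazin-1-yl)propyl group gives a 1.4-fold higher number from compound 1 to compound 3 (0.15 log units; within the scatter) and so compound 1 and compound 3 cannot be told apart in this assay, which means the propyl-linked side chain shows no measurable gain over hydrogen. Of the three groups seen at this position, only the pentyl-linked chain of compound 2 stands apart, with a higher number than both compound 1 and compound 3, so here the longer chain comes with a loss rather than the piperazine with a gain.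

The compounds shown leave open whether a plain pentyl chain without the piperazine would match compound 2 or compound 3, and whether a butyl linker to the same 4-methylpiperazine would fall with compound 1 or with compound 2. A chain ending in a morpholine or a primary amine on this nitrogen also remains an open case, and nothing available offers any explanation for these differences.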